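Swapping trifluoromethyl for phenyl on an aromatic carbon

The source may report more compounds than this note shows. Statements on the series, on what has been measured and on what is new or still open speak of the compounds shown alone.

Compound 1 `C=CC(=O)N1C(=O)CC(c2ccc(C(F)(F)F)cc2)Sc2ccccc21`: 76300 nM
Compound 2 `C=CC(=O)N1C(=O)CC(c2ccccc2Cl)Sc2ccccc21`: 80300 nM
Compound 3 `C=CC(=O)N1C(=O)CC(c2cccs2)Sc2ccccc21`: 557000 nM

In a functional assay on MOLT-4 cells (Homo sapiens) for cytotoxicity, read by CCK-8 assay, with a stated time of 24 h (on this read-out higher numbers stand for weaker inhibition and lower numbers for stronger inhibition), compound 1 and compound 2 lie within the scatter of each other, and compound 3 gives a clearly higher number. Compound 4 `C=CC(=O)N1C(=O)CC(c2ccc(-c3ccccc3)cc2)Sc2ccccc21` keeps the core of compound 1 and changes one group: phenyl in place of trifluoromethyl on an aromatic carbon. Among the compounds with values here, no measured step makes this exact swap. The only one available, a 6.9-fold higher number from compound 2 to compound 3 (0.84 log units; beyond the scatter), exchanges a whole ring group, so it bears on this change only loosely. With so little evidence, no shift beyond the scatter is expected in this assay. The estimated step is a 1.1-fold lower number from compound 1 to compound 4 (0.04 log units; within the scatter). Compound 4 is expected near 70000 nM, with an estimated range of 25000 nM to 200000 nM.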

Compound 4, half-maximal inhibitory concentration: 97500 nM
Compound 4: the middle estimate sits 1.4-fold (0.14 log units) below what was measured, and the stated range covers the measured number.
By their numbers in this assay, from the lowest: compounds 1, 2 and 4 (each within the scatter of the next); then compound 3.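

In this assay, phenyl in place of trifluoromethyl on this aromatic carbon gives a 1.3-fold higher number from compound 1 to compound 4 (0.11 log units; within the scatter), so a six-membered aromatic ring of six heavy atoms can replace a group of four here without a shift beyond the scatter. Nothing measured here gives a reason for this close match.

As far as these compounds go, whether an amine or a carboxylic acid on this same carbon would also leave the number within the scatter remains open. So does whether the same swap would behave alike on the 2-chlorophenyl or thiophen-2-yl compounds.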